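The source may report more compounds than this note shows. Statements on the series, on what has been measured and on what is new or still open speak of the compounds shown alone.

Measured so far, all in a functional assay on HT-29 cells (Homo sapiens) for cytotoxicity, read by MTT assay, with a stated time of 72 h; a lower number here means a stronger inhibitor, a higher number a weaker inhibitor:
compound 1 `Cc1ccc2nc(NC(=O)c3cn(-c4ccccc4)nc3-c3ccccc3)sc2c1` gives > 50000 nM, which is a limit of the assay.
compound 2 `O=C(Nc1nc2ccc(F)cc2s1)c1cn(-c2ccccc2)nc1-c1ccc(Cl)cc1` gives 4970 nM.
compound 3 `COc1ccc2nc(NC(=O)c3cn(-c4ccccc4)nc3-c3ccc(Cl)cc3)sc2c1` gives 18600 nM.

Compound 3 stands at the highest of the two real numbers in this assay; its nearest neighbour is compound 2, and the step of a 3.7-fold higher number from compound 2 to compound 3 (0.57 log units; beyond the scatter) is beyond the scatter. Compound 1 sits at the limit of > 50000 nM in this assay, at which 1 of the 3 values shown sits.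

The unmeasured compound 4 `Cc1ccc2nc(NC(=O)c3cn(-c4ccccc4)nc3-c3ccc(Cl)cc3)sc2c1` differs from compound 3 by methyl in place of methoxy on an aromatic carbon. Among the compounds with values here, no measured step covers this exchange. The only step shown, a 3.7-fold higher number from compound 2 to compound 3 (0.57 log units; beyond the scatter), exchanges a different group at the same aromatic carbon and moved the number up modestly. Compound 1 carries the same methyl as compound 4 but lacks the chloro on the other phenyl, and its value is only a limit, so it cannot be set against compound 3 as a step. What can be said is that the two ring substituents seen so far at this position give numbers in the weak range, and that compound 1 gives no measurable number at all.

For compound 4 a small shift toward a higher number is expected, a 1.3-fold higher number from compound 3 to compound 4 (0.13 log units; within the scatter), well within the uncertainty. Compound 4 is therefore estimated at 25000 nM, with a range from 8000 nM to 60000 nM, and a real chance that only a limit is returned.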

Compound 4, half-maximal inhibitory concentration: 23700 nM
The estimate for compound 4 lay 1.1-fold (0.02 log units) above the measured number; low and high end bracket the measured number.
By their numbers in this assay, from the lowest: compound 2; then compounds 3 and 4 (each within the scatter of the next). At a limit, above all of these: compound 1.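

In this assay, methoxy and methyl on this aromatic carbon cannot be told apart: the exchange gives a 1.3-fold higher number from compound 3 to compound 4 (0.11 log units; within the scatter), so the extra oxygen of methoxy has no readable effect on the number here. With the chloro kept, fluoro now stands apart from two other groups rather than one, since a 4.8-fold higher number from compound 2 to compound 4 (0.68 log units; beyond the scatter) joins the earlier 3.7-fold higher number from compound 2 to compound 3 (0.57 log units; beyond the scatter), and among these three groups only compound 2 has a number beyond the scatter of the others. Compound 4 also gives the first view of chloro in place of hydrogen on an aromatic carbon, with the methyl held constant, as an at least 2.1-fold lower number from compound 1 to compound 4 (0.32 log units; beyond the scatter), but only the minimum size of this step is known since compound 1 is a limit and not a number: the limit of > 50000 nM in this assay, at which 1 of the 4 values shown sits.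

From the compounds shown here alone, the true size of the chloro step stays open, as does whether the gap between fluoro and methyl would hold on a core without the chloro. Also open, going by these compounds, is how far the number moves at this aromatic carbon with other groups, such as bromo, an amine or a carboxylic acid, since three groups give too narrow a view to say whether fluoro is a special case.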